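The source may report more compounds than this note shows. Statements on the series, on what has been measured and on what is new or still open speak of the compounds shown alone.

Measured in a functional assay on GTL 16 cells for antiproliferative activity against GTL 16 cell line (Homo sapiens), read by CCK-8 assay, with a stated time of 72 h; on this read-out higher numbers stand for weaker inhibition and lower numbers for stronger inhibition: compound 1 `O=C(Nc1cccc(-c2oc3cc(-c4ccc(F)cc4)ccc3c(=O)c2O)c1)c1ccc(Cl)cc1` gives 9140 nM, compound 2 `COc1ccccc1C(=O)Nc1cccc(-c2oc3cc(-c4ccc(F)cc4)ccc3c(=O)c2O)c1` gives 6370 nM, compound 3 `Cc1cccc(C(=O)Nc2cccc(-c3oc4cc(-c5ccc(F)cc5)ccc4c(=O)c3O)c2)c1` gives 10900 nM.

Compound 3 sits within the scatter of both others: a 1.2-fold higher number from compound 1 to compound 3 (0.08 log units; within the scatter) and a 1.7-fold higher number from compound 2 to compound 3 (0.23 log units; within the scatter). The three amide aryl groups thus read alike in this assay. Compound 4 `Cc1cc(C(=O)Nc2cccc(-c3oc4cc(-c5ccc(F)cc5)ccc4c(=O)c3O)c2)ccc1F` carries fluoro in place of hydrogen on an aromatic carbon. Within the data shown here, no measured step tests a fluoro substituent at this position; the nearest comparison is compound 1, whose 4-chlorophenyl gives a number within the scatter of compound 3, and the step of a 1.4-fold lower number from compound 1 to compound 2 (0.16 log units; within the scatter) shows the same indifference to the amide aryl substituent. No step beyond the scatter is therefore expected for a 1.1-fold lower number from compound 3 to compound 4 (0.06 log units; within the scatter). Compound 4 is estimated at 9500 nM, with a range of 4500 nM to 20000 nM.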

Compound 4, half-maximal inhibitory concentration: 12100 nM
Compound 4: middle estimate off by 1.3-fold (0.11 log units), on the low side; measured number inside the range.
By their numbers in this assay, from the lowest: compounds 2, 1, 3 and 4 (each within the scatter of the next).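

In this assay, fluoro in place of hydrogen on an aromatic carbon, ortho to a methyl group and para to a large group, gives a 1.1-fold higher number from compound 3 to compound 4 (0.05 log units; within the scatter), a first direct test of this change. The 4-fluoro-3-methylphenyl group also reads alike with the other two amide aryl groups, with a 1.3-fold higher number from compound 1 to compound 4 (0.12 log units; within the scatter) and a 1.9-fold higher number from compound 2 to compound 4 (0.28 log units; within the scatter). No supporting data bear on this result.

As far as these compounds go, whether an amine, a carboxylic acid or a longer chain on this aryl group would give a step beyond the scatter stays open. Also open, from the compounds shown here alone, is whether this flat reading holds when the 4-fluorophenyl group on the shared core is replaced.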